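Reversed sulfone series: effect of a third methoxy group

This account rests on a few compounds, and the source may have more. Where it says the series, first, only, none or still open, it means among the compounds named here.

The series is followed in a functional assay on H157 cells (Homo sapiens) for antiproliferative activity, read by trypan blue exclusion; on this read-out higher numbers stand for weaker inhibition and lower numbers for stronger inhibition. Among the measured compounds shown here, compound 1 `COc1cc(OC)c(/C=C/S(=O)(=O)Cc2ccc(OC)c(OP(=O)(O)O)c2)c(OC)c1` gives 7 nM, while compound 2 `COc1cc(OC)c(/C=C/S(=O)(=O)Cc2ccc(C(=O)O)cc2)c(OC)c1` gives 17500 nM; the two values are far apart, and no single-point step connects them. Compound 3 `COc1ccc(CS(=O)(=O)/C=C/c2ccc(OC)cc2OC)cc1` carries the sulfone in the reversed sense relative to these two and a dimethoxy pattern on the styryl ring. For compound 3 the result in this assay is a limit and not a number, > 20000 nM. For the measured compounds named here, it is the one value that sits at the limit of > 20000 nM in this assay, at which 1 of the 3 values shown sits, so compound 3 stands at the weak end of everything measured here, with no number to place it more exactly.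

Compound 4 `COc1ccc(CS(=O)(=O)/C=C/c2c(OC)cc(OC)cc2OC)cc1` is the next compound in line. It differs from compound 3 by methoxy in place of hydrogen on an aromatic carbon. This brings the styryl ring to the same trimethoxy pattern as compound 1 and compound 2, but the reversed sulfone of compound 3 is kept. Going by the values given here, no measured step tells how such a change moves the read-out. The expectation is that the step of an at least 1.6-fold lower number from compound 3 to compound 4 (0.22 log units; that floor lies within the scatter) is modest and towards stronger inhibition, without reaching compound 1. Compound 4 is accordingly estimated at 12000 nM, with a range from 1500 nM to 40000 nM, and a real chance that this assay again returns only a limit.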

Compound 4, half-maximal inhibitory concentration: 30 nM
Compound 4: middle estimate off by 400-fold (2.60 log units), on the high side, outside the stated range (below it).
By their numbers in this assay, from the lowest: compound 1; then compound 4; then compound 2. At a limit, above all of these: compound 3.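

Working notes: in this assay, methoxy in place of hydrogen on an aromatic carbon of the styryl ring, ortho to a large group, gives an at least 660-fold lower number from compound 3 to compound 4 (2.82 log units; beyond the scatter), so this one position separates the weak end of the series from the strong end. The size of that step is only a floor, as compound 3 is held as a limit of the assay and not as a number: the limit of > 20000 nM in this assay, at which 1 of the 4 values shown sits.

Once the styryl ring has its third methoxy, the substituent on the other aromatic ring also matters, with methoxy in place of carboxy giving a 580-fold lower number from compound 2 to compound 4 (2.77 log units; beyond the scatter), while a hydrogen atom in place of the phosphorus-bearing group gives only a 4.3-fold higher number from compound 1 to compound 4 (0.63 log units; beyond the scatter), a modest loss beside the other two steps.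

On these data alone, it remains open whether this position needs methoxy itself or would tolerate a hydroxy group, a fluorine atom, an amine or a longer alkoxy chain. As far as these compounds go, it is also open what the true number of compound 3 is, and whether the other two methoxy groups on the styryl ring each carry a similar weight.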